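Five-membered heteroaryl exchange on a salicylic acid core

The compounds below may be only part of what the source reports. "The series", "measured", "known", "first", "only" and "open" are said of these compounds alone.

Compound 2 `O=C(O)c1cc(-c2cocn2)ccc1O` gives 110 mg/kg in a functional assay on the whole organism for inhibition, with Rattus norvegicus as the target, read by paw edema (on this read-out lower numbers stand for an effect already at smaller amounts and higher numbers for an effect only at larger amounts of compound), the highest of the three numbers shown. Compound 1 `O=C(O)c1cc(-c2ncccn2)ccc1O` gives 100 mg/kg in this assay, within the scatter of compound 2. Compound 3 `CC(=O)Oc1ccc(-n2cccc2)cc1C(=O)O` gives 42 mg/kg in this assay, a lower number that lies beyond the scatter of compound 2; compound 3 differs from compound 2 in more than one place, so its two values are all that can be said of it. Compound 4 `O=C(O)c1cc(-n2nccn2)ccc1O` differs from compound 2 as follows: 2H-1,2,3-triazol-2-yl in place of 1,3-oxazol-4-yl on an aromatic carbon. Going by the values given here, no measured step of this kind exists among the three compounds. In this assay compound 4 is expected to show a small step from compound 2 a 1.2-fold lower number from compound 2 to compound 4 (0.09 log units; within the scatter), not beyond the scatter. Compound 4 is estimated at 90 mg/kg, within 45 mg/kg to 180 mg/kg.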

Compound 4, dose for half-maximal effect: 150 mg/kg
Beside the measured number, compound 4's estimate is 1.7-fold (0.22 log units) below it, and the stated range covers the measured number.
By their numbers in this assay, from the lowest: compound 3; then compounds 1, 2 and 4 (each within the scatter of the next).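

In this assay, going by these compounds alone, the exchange of 1,3-oxazol-4-yl for 2H-1,2,3-triazol-2-yl gives a 1.4-fold higher number from compound 2 to compound 4 (0.13 log units; within the scatter), the only step at this position that can be read. At this place, meta to a carboxy group and para to a hydroxy group, a five-membered aromatic ring with 3 hetero atoms thus stands in for one with 2 without a change beyond the scatter. Nothing shown gives a reason for this result. From the compounds shown here alone, whether an amine or a longer alkyl chain at this place would move the number beyond the scatter remains open.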